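The source may hold more compounds than are shown below. What is called first, only, known or untested is meant among the compounds shown, and "the series" means these compounds.

Measured so far:
compound 1 `C=C1CN/C(=N/c2ccccc2)S1` — > 100000 nM
compound 2 `COc1ccc(/C=C2/CN(C)/C(=N/c3ccc(Cl)cc3)S2)cc1` — 9800 nM

In a functional assay on HCT-116 cells (Homo sapiens) for antiproliferative activity, read by MTT assay, with a stated time of 72 h (a lower number here means a stronger inhibitor, a higher number a weaker inhibitor), compound 1 gives > 100000 nM, which is a limit of the assay and not a number. Compound 2 gives 9800 nM in this assay, the only number shown; the other value recorded is the limit of > 100000 nM in this assay, at which 1 of the 2 values shown sits, so compound 2 is the sole compound in the series with a measured figure and there is nothing to rank it against.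

Compound 3 `COc1ccc(/C=C2/CN(C)/C(=N/c3ccc(C(F)(F)F)cc3)S2)cc1` differs from compound 2 by trifluoromethyl in place of chloro on an aromatic carbon, the trifluoromethyl standing on an aromatic carbon of a six-membered aromatic ring of carbon only, para to a large group. For the measured compounds named here, no step between two measured compounds exists, so no measured precedent for a swap of this kind is at hand. The expectation is a step of no size beyond the scatter, in either direction, for the move from compound 2 to compound 3 in this assay, as expressed in a 1.2-fold lower number from compound 2 to compound 3 (0.09 log units; within the scatter). On that basis compound 3 is estimated at 8000 nM in this assay, with a range from 3000 nM to 25000 nM.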

Compound 3, half-maximal inhibitory concentration: 34300 nM
Beside the measured number, compound 3's estimate is 4.3-fold (0.63 log units) below it, and the stated range ends below it.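

In this assay, the series now has its first readable step, at an aromatic carbon of a six-membered aromatic ring of carbon only, para to a large group: trifluoromethyl in place of chloro gives a 3.5-fold higher number from compound 2 to compound 3 (0.54 log units; beyond the scatter). This position is therefore not indifferent to the change, since the pair separates beyond the scatter and the chloro compound, compound 2, is the stronger of the two. That reading rests on a single pair and holds for these two compounds only, and nothing recorded for the series bears on the reason for the step.

Among compounds that differ only at this carbon, just chloro and trifluoromethyl are shown, so it remains open how a fluoro group, a nitrile, an amine or a carboxylic acid would read here, and whether the higher number belongs to trifluoromethyl in particular or to departures from chloro in general. As far as these compounds go, whether the step keeps its size when the shared core is changed elsewhere also remains open.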